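The source may hold more compounds than are shown below. What is called first, only, known or untested is meant among the compounds shown, and "the series" means these compounds.

Compound 1 `CC(C)(C)c1ccc(-c2cn(C/C=C3\OC(=O)C(OCc4ccccc4)=C3OCc3ccccc3)nn2)cc1` is tested in a functional assay on HCT-116 cells (Homo sapiens) for antiproliferative activity, read by MTT assay, with a stated time of 24 h; a higher number here means a weaker inhibitor, a lower number a stronger inhibitor. In this assay compound 1 gives only a limit of the assay, > 100000 nM, so its standing on the numbers shown is that limit itself (the limit of > 100000 nM in this assay, at which 1 of the 2 values shown sits). Compound 2 `COC1=C(OC)C(O)(CCn2cc(-c3ccccc3)nn2)NC1=O` gives 46300 nM in this assay. Compound 3 `O=C1O/C(=C\Cn2cc(-c3ccccc3)nn2)C(OCc2ccccc2)=C1OCc1ccccc1` differs from compound 1 by hydrogen in place of tert-butyl on an aromatic carbon. Within the data shown here, no measured pair shows this change, and with compound 1 sitting at a limit no step beyond the scatter can be read in either direction, so none is assumed. Compound 3 is expected at 100000 nM, between 30000 nM and 300000 nM. The expected step is a number no higher from compound 1 to compound 3 (the limit leaves the size open), and a limit rather than a number is the more likely outcome.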

Compound 3, half-maximal inhibitory concentration: > 100000 nM
Compound 3 ended at the assay's limit; the forecaster's own chance of this, stated with the estimate: 60%; the middle value lies on the limit itself.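

Compound 1 and compound 3 both sit at a limit of the assay, so no step can be read between them: the limit of > 100000 nM in this assay, at which 2 of the 3 values shown sit.

From the compounds shown here alone, the effect of the 4-(tert-butyl)phenyl to phenyl change on the shared core stays open, with no number on either side.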